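This account rests on a few compounds, and the source may have more. Where it says the series, first, only, none or still open, it means among the compounds named here.

Compound 1 `C[C@H](c1ccc(C(=O)NCCC(=O)O)cc1)N1C(=O)C(c2cccc(OC(F)(F)F)c2)=N[C@]12CC[C@@H](C(C)(C)C)CC2` and compound 2 `CC(C)(C)[C@H]1CC[C@]2(CC1)N=C(c1ccc(Cl)cc1)C(=O)N2Cc1ccc(C(=O)NCCC(=O)O)cc1` were both tested in an assay on membranes from liver for displacement of a labelled ligand from Glucagon receptor (Mus musculus), read by scintillation counting, with a stated time of 60 min; on this read-out lower numbers stand for stronger inhibition and higher numbers for weaker inhibition. In this assay compound 1 gives 1500 nM. For compound 2 this assay reports only a limit, > 10000 nM, and not a number; that limit, (the limit of > 10000 nM in this assay, at which 1 of the 2 values shown sits), is where one of the two values shown sits. Going by the values given here, compound 1 and compound 2 differ in more than one place, so their two numbers show only that compound 1 lies inside the measurable range while compound 2 lies at its edge.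

Compound 3 `CC(C)(C)[C@H]1CC[C@]2(CC1)N=C(c1ccc(C(F)(F)F)cc1)C(=O)N2Cc1ccc(C(=O)NCCC(=O)O)cc1` has not yet been measured. It differs from compound 2 in a single place: trifluoromethyl in place of chloro on an aromatic carbon. Since compound 2 already sits at the limit and the change touches one group at the edge of the molecule, no move beyond the usual scatter is expected in either direction. The expected step is an at least 1.1-fold lower number from compound 2 to compound 3 (0.04 log units; that floor lies within the scatter), which is within the usual scatter of this assay. Compound 3 is therefore estimated to give about 9000 nM in this assay, with a likely range from 2500 nM to 30000 nM, and a fair chance that the assay again returns only a limit.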

Compound 3, half-maximal inhibitory concentration: 9600 nM
Compound 3: the middle estimate sits 1.1-fold (0.03 log units) below what was measured, and the stated range covers the measured number.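

In this assay, going by these compounds alone, the change from 4-chlorophenyl to 4-(trifluoromethyl)phenyl gives an at least 1.0-fold lower number from compound 2 to compound 3 (0.01 log units; that floor lies within the scatter), so on this aromatic carbon, replacing a single chlorine with a group of four heavy atoms produces no step that can be told apart from the ordinary spread of repeat measurements. This figure is only a floor, and the true gap could be larger, because one end of the step is not a number: the limit of > 10000 nM in this assay, at which 1 of the 3 values shown sits.

What is new is that compound 3 gives 9600 nM in this assay, a real number rather than a limit, so trifluoromethyl at this position still leaves a readable value close to the top of the measurable range.

The compounds shown leave open whether another group on this same carbon, such as a methoxy, a nitrile or an amine, would move the number beyond the scatter. They also leave open whether the swap from chloro to trifluoromethyl would read the same way on a compound lying further inside the measurable range, where both ends of the step would be true numbers.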